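Methyl Gives Way to Methoxy on the Aryl Urea

This account rests on a few compounds, and the source may have more. Where it says the series, first, only, none or still open, it means among the compounds named here.

Compound 3 `CCc1nc2ccccc2c(=O)n1NC(=O)Nc1ccc(C)cc1` gives 55% in a functional assay on the whole organism (strain albino) with Mus musculus as the target, at a dose of 100 mg/kg by the intraperitoneal route (on this read-out higher numbers stand for more inhibition at the one dose given (going by the name of the read-out) and lower numbers for less inhibition), the highest of the three numbers shown, yet within the scatter of compound 1 `COc1ccc(NC(=O)Nn2c(-c3ccccc3)nc3ccccc3c2=O)cc1` at 52% and of compound 2 `CCOc1ccc(NC(=O)Nn2c(CC)nc3ccccc3c2=O)cc1` at 50%. Compound 4 `CCc1nc2ccccc2c(=O)n1NC(=O)Nc1ccc(OC)cc1` differs from compound 3 by methoxy in place of methyl on an aromatic carbon. Among the compounds with values here, the only measured step at an aromatic carbon of this kind, a number 5 percentage points higher from compound 2 to compound 3 (within the scatter), stayed within the scatter, and compound 1, which also carries a methoxy on an aromatic carbon of its own core, sits within the scatter of compound 3. Compound 4 is therefore expected to show no step beyond the scatter, a number 3 percentage points lower from compound 3 to compound 4 (within the scatter). The estimated value of compound 4 in this assay is 52%, with a range from 40% to 64%.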

Compound 4, a percentage reported as inhibition, in the whole organism at one dose (the size of the read-out at that dose, not a potency): 48%
The estimate for compound 4 lay 4 percentage points above the measured number; the range from low to high includes it.
By their numbers in this assay, from the lowest: compounds 4, 2, 1 and 3 (each within the scatter of the next).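

In this assay, methoxy in place of methyl on the aromatic carbon gives a number 7 percentage points lower from compound 3 to compound 4 (within the scatter) and so adds a second step at this kind of place that stays within the scatter. Methoxy in place of ethoxy gives a number 2 percentage points lower from compound 2 to compound 4 (within the scatter) while ethyl in place of phenyl on the core gives a number 4 percentage points lower from compound 1 to compound 4 (within the scatter) and thus, among these four compounds, neither change separates compound 4 from its neighbours. Nothing measured here offers an explanation for these numbers.

Going by these compounds, whether an amine or a carboxylic acid in the place of the methoxy would move the number beyond the scatter stays open, as does the effect of a longer chain in place of the ethyl on the core.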